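Replacing propyl with 2-methoxyphenyl on an amide-type nitrogen

The compounds below may be only part of what the source reports. "The series", "measured", "known", "first", "only" and "open" are said of these compounds alone.

In a functional assay on MDA-MB-231 cells (Homo sapiens) for antiproliferative activity, read by MTT assay, with a stated time of 48 h (a higher number here means a weaker inhibitor, a lower number a stronger inhibitor), compound 1 (`C=CS(=O)(=O)N1CCN(c2ncnc3sc(-c4cccs4)cc23)CC1`) gives 34100 nM as its half-maximal inhibitory concentration. Compound 2 (`CCCNC(=O)N1CCN(c2ncnc3sc(-c4ccc(N5CCN(C)CC5)cc4)cc23)CC1`) gives 8330 nM in the same readout. That is the lower of the two numbers, so compound 2 is the stronger inhibitor of this pair, by a gap beyond the usual scatter. These two compounds differ in more than one place, so the pair isolates no single structural change.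

Compound 3 (`COc1ccccc1NC(=O)N1CCN(c2ncnc3sc(-c4ccc(N5CCN(C)CC5)cc4)cc23)CC1`) departs from compound 2 in one place, with 2-methoxyphenyl in place of propyl on an amide-type nitrogen. Among the measured compounds shown here, no measured pair tests a change at this position, so the expectation is weakly grounded and starts from compound 2 at 8330 nM as its anchor. In this assay a small move toward a lower number is expected, estimated as a 1.7-fold lower number from compound 2 to compound 3 (0.22 log units; within the scatter) and not expected to clear the scatter. The estimate for compound 3 is 5000 nM (expected range 1500 nM to 15000 nM).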

Compound 3, half-maximal inhibitory concentration: 23200 nM
The estimate for compound 3 lay 4.6-fold (0.67 log units) below the measured number; measured number above the stated range.
By their numbers in this assay, from the lowest: compound 2; then compounds 3 and 1 (each within the scatter of the next).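

In this assay, among the compounds shown here, this is the first reading of a single change at the amide-type nitrogen: 2-methoxyphenyl in place of propyl gives a 2.8-fold higher number from compound 2 to compound 3 (0.44 log units; beyond the scatter), a modest loss of potency. The position therefore responds to the group it carries, and with the rest of compound 2 held fixed, the open propyl chain reads better than the 2-methoxyphenyl group with its six-membered aromatic ring. No measurement here accounts for the step, and it cannot be assigned to the ring, to the methoxy oxygen or to the overall size of the group.

One pair gives a direction for these two groups only, not a trend, and it leaves open whether the loss follows the aromatic ring itself or its methoxy group; plain phenyl, benzyl or a longer chain such as butyl on the same nitrogen would separate these readings. On these data alone, whether the change would read the same way with a different group elsewhere on the shared core also stays open, as compound 1 differs from compound 2 in more than one place.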